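The compounds below may be only part of what the source reports. "The series", "measured", "known", "first", "only" and "open" are said of these compounds alone.

Measured in an assay (Rattus norvegicus) for binding affinity to prostacyclin receptor (Homo sapiens), read by radioligand binding; on this read-out lower numbers stand for stronger inhibition and higher numbers for weaker inhibition:
compound 1 `c1ccc(Sc2ccc(NC3=NCCN3)cc2)cc1` gives 794 nM
compound 2 `CCOc1ccc(Sc2ccc(NC3=NCCN3)cc2)cc1` gives 39.8 nM
compound 3 `FC(F)(F)c1ccc(Sc2ccc(NC3=NCCN3)cc2)cc1` gives 50.1 nM

Compound 1 has the highest number of the three in this assay. Compound 3 is the nearest to it, compound 2 the furthest: a 16-fold lower number from compound 1 to compound 3 (1.20 log units; beyond the scatter) and a 20-fold lower number from compound 1 to compound 2 (1.30 log units; beyond the scatter). The two substituted analogues sit close together, a 1.3-fold higher number from compound 2 to compound 3 (0.10 log units; within the scatter).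

Compound 4 `c1cc(SC2CCCCC2)ccc1NC1=NCCN1` differs from compound 1 in one place: cyclohexyl in place of phenyl on a sulfur. Going by the values given here, none of the measured steps bears directly on this change. Among the compounds with values here, both large steps from compound 1 keep the phenyl on the sulfur and place a group on its aromatic carbon; no measured pair exchanges the phenyl for a non-aromatic ring. Within the data shown here, the series therefore gives no direction for the step in this assay, and the expectation must rest on compound 1 alone with a wide allowance either way. For compound 4 the estimate in this assay is 800 nM, with a range from 150 nM to 4000 nM. This estimate corresponds to an expected step of a 1.0-fold higher number from compound 1 to compound 4 (0.00 log units; within the scatter).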

Compound 4, inhibition constant: 3160 nM
For compound 4 the middle estimate is 4.0-fold (0.60 log units) below the measured one; the measured number falls inside the stated range.
By their numbers in this assay, from the lowest: compounds 2 and 3 (each within the scatter of the next); then compound 1; then compound 4.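

In this assay, the ring on the sulfur proves to be a position that responds in its own right: cyclohexyl in place of phenyl gives a 4.0-fold higher number from compound 1 to compound 4 (0.60 log units; beyond the scatter). The earlier steps shown here only added groups to the aromatic carbon of the phenyl and went to lower numbers, whereas this exchange of an aromatic ring for a non-aromatic ring, with the heavy-atom count unchanged, goes to a higher number, though this rests on one pair. Nothing measured here accounts for the shift between the two rings.

Whether ethoxy or trifluoromethyl would lower the number on cyclohexyl as they do on phenyl remains open, as the compounds shown carry them on phenyl only. Also open, from the compounds shown here alone, is how a piperidine ring, a pyridine ring or a benzyl group on the sulfur would read.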